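Swapping one small aromatic ring for another on a kinase inhibitor

This account rests on a few compounds, and the source may have more. Where it says the series, first, only, none or still open, it means among the compounds named here.

Of the compounds shown here, three have so far been tested in an assay on isolated protein for inhibition of eIF-2-alpha kinase GCN2 (Homo sapiens); on this read-out higher numbers stand for weaker inhibition and lower numbers for stronger inhibition. Compound 1 `CCn1cc(Nc2ncc3c(C)nn(-c4ccc(C#N)cc4)c3n2)cn1` gives 56 nM. Compound 2 `COCCNC(=O)[C@H]1C[C@H](Nc2ncc3c(Br)nn(-c4ccc5ncccc5c4)c3n2)C1` gives 40 nM. Compound 3 `CNC(=O)[C@]1(C)CC[C@@H](Nc2ncc3c(Br)nn(-c4ccc(-c5nnc(C)o5)cc4)c3n2)C1` gives 16 nM, the lowest number of the three, and its distance to compound 2 and to compound 1 is in each case beyond the usual scatter, so compound 3 is the strongest inhibitor among them on this read-out.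

Compound 4 `CNC(=O)[C@]1(C)CC[C@@H](Nc2ncc3c(Br)nn(-c4ccc(-c5cnc(C)s5)cc4)c3n2)C1` shares almost everything with compound 3. Among the measured compounds shown here, the only change is 2-methyl-1,3-thiazol-5-yl in place of 5-methyl-1,3,4-oxadiazol-2-yl on an aromatic carbon, in words 2-methyl-1,3-thiazol-5-yl in place of 5-methyl-1,3,4-oxadiazol-2-yl on an aromatic carbon. For the measured compounds named here, no measured pair so far differs in exactly this way, so there is no measured step to lean on, and the two rings are the same size and sit in the same place. The step of a 1.3-fold higher number from compound 3 to compound 4 (0.10 log units; within the scatter) is therefore expected to be small, either way, and likely not beyond the scatter. Compound 4 is estimated at 20 nM in this assay, with a range from 7 nM to 60 nM.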

Compound 4, half-maximal inhibitory concentration: 27 nM
Estimate against measurement, compound 4: 1.4-fold (0.13 log units) below; measured number inside the range.
By their numbers in this assay, from the lowest: compounds 3, 4, 2 and 1 (each within the scatter of the next, the first and the last beyond it).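

In this assay, putting 2-methyl-1,3-thiazol-5-yl in place of 5-methyl-1,3,4-oxadiazol-2-yl gives a 1.7-fold higher number from compound 3 to compound 4 (0.23 log units; within the scatter), so on this aromatic carbon, para to a large group, the two rings cannot be told apart on this read-out. The pair also shows that the make-up of the ring can differ without a step beyond the scatter: a ring with 3 hetero atoms and 3 hydrogen-bond acceptors gives way to one with 2 hetero atoms and 2 hydrogen-bond acceptors, with sulfur present and oxygen gone, though this is a single pair and supports no general rule. No independent measurement on either ring is available to explain this result.

On these data alone, both rings are five-membered, aromatic and methyl-bearing, so it remains open how this position would respond to something quite different, such as a carboxylic acid or an aminomethyl group in place of the ring. As far as these compounds go, it is equally open what a longer chain, such as propyl, would do in place of the methyl on the thiazole.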